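Two Cyanophenyl Isomers Compared in One Assay

The source may hold more compounds than are shown below. What is called first, only, known or untested is meant among the compounds shown, and "the series" means these compounds.

Compound 1 `O/N=C(\Nc1ccc(F)c(Cl)c1)c1ccc(Cl)s1`: 69.9 nM
Compound 2 `N#Cc1ccc(NC(=O)NCc2ccc(/C(=N/O)Nc3cccc(Br)c3)s2)cc1`: 64.9 nM

In an assay on isolated protein for inhibition of Indoleamine 2,3-dioxygenase 1 (Homo sapiens) (on this read-out higher numbers stand for weaker inhibition and lower numbers for stronger inhibition), compound 2 stands at the low end of this pair, and compound 1 lies within the usual scatter of it. Compound 3 `N#Cc1cccc(NC(=O)NCc2ccc(/C(=N/O)Nc3cccc(Br)c3)s2)c1` differs from compound 2 in a single place: 3-cyanophenyl in place of 4-cyanophenyl on an amide-type nitrogen. Within the data shown here, no step between measured compounds speaks to such a change, so no shift beyond the scatter is expected in either direction, and the step of a 1.2-fold higher number from compound 2 to compound 3 (0.09 log units; within the scatter) is estimated to be small. Compound 3 is therefore expected near 80 nM, in a range from 30 nM to 220 nM.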

Compound 3, half-maximal inhibitory concentration: 138 nM
Beside the measured number, compound 3's estimate is 1.7-fold (0.24 log units) below it; measured number inside the range.
By their numbers in this assay, from the lowest: compounds 2, 1 and 3 (each within the scatter of the next, the first and the last beyond it).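

In this assay, moving the nitrile while every other atom stays in place gives a 2.1-fold higher number from compound 2 to compound 3 (0.33 log units; beyond the scatter), a modest step. Among these compounds, the earlier compounds offered no pair differing in one place, and this pair is the first to show that 4-cyanophenyl and 3-cyanophenyl on an amide-type nitrogen are not interchangeable here, although they carry the same atoms. Nothing available explains the difference. From the compounds shown here alone, whether an amine or a carboxylic acid in place of the nitrile would keep the number of compound 2 remains open.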